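Lengthening a piperazine substituent in two related cores

This account rests on a few compounds, and the source may have more. Where it says the series, first, only, none or still open, it means among the compounds named here.

Compound 1 `Cc1ccccc1Nc1nc(Nc2ccc(N3CCN(C)CC3)cn2)ncc1Cl` and compound 3 `Cc1ccccc1Nc1nc(Nc2ccc(N3CCN(C)CC3)cc2)ncc1Cl` share much of their framework, but the difference between their two cores is not broken down here. In a functional assay on MDA-MB-231 cells (Homo sapiens) for inhibition, read by CCK-8 assay, with a stated time of 48 h (a higher number here means a weaker inhibitor of growth, a lower number a stronger inhibitor of growth), compound 1 gives 7470 nM, and compound 3 gives 7020 nM. Compound 2 `CCN1CCN(c2ccc(Nc3ncc(Cl)c(Nc4ccccc4C)n3)nc2)CC1` differs from compound 1 by methyl in place of hydrogen on a saturated chain carbon bound to an amine nitrogen in a ring. In this assay compound 2 reaches only a limit of the assay, > 100000 nM. That change produced an at least 13-fold higher number from compound 1 to compound 2 (1.12 log units; beyond the scatter). Compound 4 `CCN1CCN(c2ccc(Nc3ncc(Cl)c(Nc4ccccc4C)n3)cc2)CC1` arises from compound 3 by the same change, (methyl in place of hydrogen on a saturated chain carbon bound to an amine nitrogen in a ring). Compound 4 is expected to show a step of a 14-fold higher number from compound 3 to compound 4 (1.15 log units; beyond the scatter) because an at least 13-fold higher number from compound 1 to compound 2 (1.12 log units; beyond the scatter) ran into the limit (the limit of > 100000 nM in this assay, at which 1 of the 3 values shown sits). Compound 4 is therefore estimated at 100000 nM, with an expected range from 30000 nM to 300000 nM.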

Compound 4, concentration for 50% growth inhibition: 3040 nM
For compound 4 the middle estimate is 33-fold (1.52 log units) above the measured one; measured number outside the range, below it.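

The change from 4-methylpiperazin-1-yl to 4-ethylpiperazin-1-yl does not carry over from one core to the other, and the two steps differ by more than the scatter: the same change on two cores in this assay, an at least 13-fold higher number (1.12 log units; beyond the scatter) from compound 1 to compound 2 and a 2.3-fold lower number (0.36 log units; beyond the scatter) from compound 3 to compound 4, at least 30-fold (1.49 log units) apart, beyond the scatter of two such steps. Going by these compounds, on the core of compound 3, the change gives a 2.3-fold lower number from compound 3 to compound 4 (0.36 log units; beyond the scatter) in this assay, the opposite direction to the step on the core of compound 1, whose full size remains unknown: the limit of > 100000 nM in this assay, at which 1 of the 4 values shown sits. With one pair on each core, this shows that the outcome depends on the core, but it does not show what in the core is responsible.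

On these data alone, it remains open how a longer chain, such as propyl, would behave on each core. A hydrogen in place of the methyl or ethyl on the piperazine nitrogen is also untested among the compounds shown.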